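A pyrrole isomer swap from compound 3 to compound 4

The compounds below may be only part of what the source reports. "The series", "measured", "known", "first", "only" and "open" are said of these compounds alone.

Three compounds share one core and differ only in the group on the double-bonded chain carbon. In a functional assay on JAR cells (Homo sapiens) for inhibition, read by MTT assay, with a stated time of 72 h, tested at 10 uM (a lower number here means less inhibition, a higher number more inhibition at the concentration tested (going by the name of the read-out)), compound 1 `CCOC(=O)C1=C(Nc2ccccc2)S/C(=C\c2ccccc2)C1=O` gives 20.3%, compound 2 `CCOC(=O)C1=C(Nc2ccccc2)S/C(=C\c2ccccc2O)C1=O` gives 89.4%, and compound 3 `CCOC(=O)C1=C(Nc2ccccc2)S/C(=C\c2ccc[nH]2)C1=O` gives 49.2%, which places compound 3 second highest of the three. The steps among them are a number 69.1 percentage points higher from compound 1 to compound 2 (beyond the scatter), a number 28.9 percentage points higher from compound 1 to compound 3 (beyond the scatter) and a number 40.2 percentage points lower from compound 2 to compound 3 (beyond the scatter).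

Compound 4 `CCOC(=O)C1=C(Nc2ccccc2)S/C(=C\c2cc[nH]c2)C1=O` differs from compound 3 by 1H-pyrrol-3-yl in place of 1H-pyrrol-2-yl on a double-bonded chain carbon bound to a double-bonded ring carbon. Going by the values given here, no measured step exchanges one pyrrole isomer for the other; the steps from compound 1 and compound 2 to compound 3 put a 1H-pyrrol-2-yl in place of a phenyl or a 2-hydroxyphenyl, a different change, so they bear on this step only loosely. With both groups counted identically, the step from compound 3 to compound 4 is expected to stay within the scatter, a number 0.2 percentage points lower from compound 3 to compound 4 (within the scatter). In this assay compound 4 is therefore estimated at 49%, within 25% to 75%.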

Compound 4, a percentage reported as inhibition, at one concentration (the size of the read-out at that concentration, not a potency): 19.5%
Compound 4: the middle estimate sits 29.5 percentage points above what was measured, and the stated range ends above it.
By their numbers in this assay, from the lowest: compounds 4 and 1 (each within the scatter of the next); then compound 3; then compound 2.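

In this assay, the attachment point of the pyrrole on the double-bonded chain carbon matters on its own: with the same atoms joined differently, the change to 1H-pyrrol-3-yl gives a number 29.7 percentage points lower from compound 3 to compound 4 (beyond the scatter), so the rise seen with 1H-pyrrol-2-yl over phenyl does not extend to pyrrole groups in general. The 1H-pyrrol-3-yl group in place of phenyl gives a number 0.8 percentage points lower from compound 1 to compound 4 (within the scatter), and in place of 2-hydroxyphenyl it gives a number 69.9 percentage points lower from compound 2 to compound 4 (beyond the scatter), which leaves only 2-hydroxyphenyl and 1H-pyrrol-2-yl clear of the phenyl level among these four compounds. Nothing available accounts for the difference between the two pyrrole isomers.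

The compounds shown leave open how a furyl, a thienyl or a methoxyphenyl group would behave at this position. They also leave open whether the gap between the isomers holds outside this assay.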